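The compounds below may be only part of what the source reports. "The series", "measured", "known", "first", "only" and "open" are said of these compounds alone.

Working notes on the series.

Compound 1 `COc1cccc2c1c(C(=O)/C=C(\O)C(=O)O)cn2Cc1ccccc1F` is the reference point. Among the measured compounds shown here, in an ADME assay on MT4 cells (Homo sapiens) for cytotoxicity, read by MTT assay (on this read-out lower numbers stand for higher toxicity in this test and higher numbers for lower toxicity in this test), compound 1 gives 70500 nM, the highest of the two numbers measured so far. For the measured compounds named here, its nearest neighbour is compound 2 `COc1cccc2c1c(C(=O)/C=C(\O)C(=O)O)cn2Cc1cc(F)cc(F)c1`, which in this assay gives 29500 nM; the step of a 2.4-fold lower number from compound 1 to compound 2 (0.38 log units; beyond the scatter) is the only measured step in the set, and it concerns the aryl group on the saturated chain carbon bound to the aromatic nitrogen, not the acid end of the molecule.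

Compound 3 `CCOC(=O)/C(O)=C/C(=O)c1cn(Cc2ccccc2F)c2cccc(OC)c12` is not yet measured. It differs from compound 1 by ethyl in place of hydrogen on an oxygen next to a carbonyl group. Going by the values given here, no measured step touches this oxygen, so the step from compound 1 to compound 2 does not bear on it directly; it only shows that a single change on the shared core can move this assay beyond the scatter.

Among the compounds with values here, with no comparable step, the expectation for compound 3 stays close to compound 1, with wide bounds in both directions; the step of a 1.6-fold lower number from compound 1 to compound 3 (0.19 log units; within the scatter) is expected to lie near the scatter. Compound 3 is estimated at 45000 nM, within 15000 nM to 130000 nM.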

Compound 3, half-maximal cytotoxic concentration: 63300 nM
The estimate for compound 3 lay 1.4-fold (0.15 log units) below the measured number; the range from low to high includes it.
By their numbers in this assay, from the lowest: compound 2; then compounds 3 and 1 (each within the scatter of the next).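

In this assay, the oxygen of the carboxy group now has a measured step of its own: ethyl in place of hydrogen on an oxygen next to a carbonyl group gives a 1.1-fold lower number from compound 1 to compound 3 (0.05 log units; within the scatter) and so stays inside the usual scatter. Among the compounds shown here, with the 2-fluorophenyl group held fixed, this read-out therefore does not separate the carboxy form from the ethoxycarbonyl form, whereas the one earlier step, on the aryl group, is a 2.4-fold lower number from compound 1 to compound 2 (0.38 log units; beyond the scatter) and lies beyond the scatter. Nothing on hand explains why the two forms read alike.

On these data alone, the step rests on a single pair with one group on the nitrogen, so it remains open whether ethyl in place of hydrogen on this oxygen would also stay within the scatter on compound 2, with its 3,5-difluorophenyl group. As far as these compounds go, it also remains open whether a methyl group or a longer chain on this oxygen, or an amide in place of the ester, would read the same in this assay as the ethyl group does.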